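The source may report more compounds than this note shows. Statements on the series, on what has been measured and on what is new or still open speak of the compounds shown alone.

Measured so far in a functional assay on PC-3 cells (Homo sapiens) for antiproliferative activity, read by MTT assay, with a stated time of 24 h; on this read-out lower numbers stand for stronger inhibition and higher numbers for weaker inhibition:
Compound 1 `CCn1c(C(=O)N[C@H](C)C(=O)OC)ccc1C(CC)(CC)c1ccc(OCS(=O)(=O)c2ccccc2)c(C)c1` reaches only the assay limit, > 50000 nM.
Compound 2 `CCn1c(C(=O)N[C@@H](C)CO)ccc1C(CC)(CC)c1ccc(OCS(=O)(=O)c2ccccc2)c(C)c1` gives 9520 nM.
Compound 3 `CCn1c(C(=O)NCCCO)ccc1C(CC)(CC)c1ccc(OCS(=O)(=O)c2ccccc2)c(C)c1` gives 11300 nM.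

Compound 2 stands together with compound 3: the step of a 1.2-fold higher number from compound 2 to compound 3 (0.07 log units; within the scatter) is within the scatter, so the two cannot be ordered. Both sit clearly apart from compound 1, an at least 5.2-fold lower number from compound 1 to compound 2 (0.72 log units; beyond the scatter) and an at least 4.4-fold lower number from compound 1 to compound 3 (0.64 log units; beyond the scatter), though that comparison rests on a limit (the limit of > 50000 nM in this assay, at which 1 of the 3 values shown sits). Compound 4 `CCn1c(C(=O)N[C@@H](CO)CCO)ccc1C(CC)(CC)c1ccc(OCS(=O)(=O)c2ccccc2)c(C)c1` carries 3-hydroxy-1-(hydroxymethyl)propyl in place of 1-(hydroxymethyl)ethyl on an amide-type nitrogen. Among the compounds with values here, the only measured step bearing on it is a 1.2-fold higher number from compound 2 to compound 3 (0.07 log units; within the scatter), where 3-hydroxypropyl replaced 1-(hydroxymethyl)ethyl on the same nitrogen without moving the number beyond the scatter; no measured step matches the entering group exactly. The step of a 1.0-fold lower number from compound 2 to compound 4 (0.00 log units; within the scatter) is therefore expected to stay within the scatter. Compound 4 is estimated at 9500 nM, with a range from 4000 nM to 22000 nM.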

Compound 4, half-maximal inhibitory concentration: 14100 nM
Estimate against measurement, compound 4: 1.5-fold (0.17 log units) below, and the stated range covers the measured number.
By their numbers in this assay, from the lowest: compounds 2, 3 and 4 (each within the scatter of the next). At a limit, above all of these: compound 1.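

In this assay, 3-hydroxy-1-(hydroxymethyl)propyl in place of 1-(hydroxymethyl)ethyl on the amide-type nitrogen gives a 1.5-fold higher number from compound 2 to compound 4 (0.17 log units; within the scatter) and hydroxymethyl in place of hydrogen on the chain carbon gives a 1.2-fold higher number from compound 3 to compound 4 (0.10 log units; within the scatter), so a further hydroxymethyl does not separate these compounds. The larger group still stands apart from the methyl ester, with an at least 3.5-fold lower number from compound 1 to compound 4 (0.54 log units; beyond the scatter). That comparison rests on compound 1, whose value is a limit: the limit of > 50000 nM in this assay, at which 1 of the 4 values shown sits.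

On these data alone, whether an amine or a carboxylic acid on this nitrogen would move the number beyond the scatter remains open. So does the effect of a longer hydroxyalkyl chain.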